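Methoxy gives way to methyl: compound 2 to compound 3

The source may report more compounds than this note shows. Statements on the series, on what has been measured and on what is new or still open speak of the compounds shown alone.

In a functional assay on CEM-SS cells (Homo sapiens) for cytotoxicity (a higher number here means a weaker inhibitor, a lower number a stronger inhibitor), compound 1 `Clc1cc2nc(Br)n(Cc3ccccc3)c2cc1Cl` gives > 100000 nM, which is a limit of the assay and not a number. Going by the values given here, compound 2 `COc1ccc(Cn2c(Br)nc3cc(Cl)c(Cl)cc32)cc1` gives 60000 nM, the only actual number so far. Compound 3 `Cc1ccc(Cn2c(Br)nc3cc(Cl)c(Cl)cc32)cc1` carries methyl in place of methoxy on an aromatic carbon, para to a large group: methyl in place of methoxy on an aromatic carbon. Among the compounds with values here, one measured step bears on this, the one that put the methoxy there in place of hydrogen, and it came to an at least 1.6-fold lower number from compound 1 to compound 2 (0.22 log units; that floor lies within the scatter). Since that step does not clearly exceed the scatter, swapping the methoxy for methyl is not expected to move the number much in this assay. The expected step is a 1.2-fold higher number from compound 2 to compound 3 (0.07 log units; within the scatter), which would stay within the scatter. For compound 3 the estimate is 70000 nM, with an expected range of 30000 nM to 100000 nM.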

Compound 3, half-maximal inhibitory concentration: > 100000 nM
Compound 3: no number, only a limit (the forecaster's own chance of this, stated with the estimate: 30%); at least 1.4-fold (0.15 log units) between middle value and limit.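

In this assay, putting methyl in place of methoxy on the aromatic carbon gives an at least 1.6-fold higher number from compound 2 to compound 3 (0.22 log units; that floor lies within the scatter), so this floor alone does not show that the two groups differ. The new result does show that a methyl here yields no actual number, which leaves compound 2, with its methoxy, as the only compound shown that has one. The step between compound 1 and compound 3 cannot be read, because both values are limits of the assay and not numbers: the limit of > 100000 nM in this assay, at which 2 of the 3 values shown sit.

On these data alone, how much compound 2 truly differs from compound 1 and compound 3 stays open. Also open, as far as these compounds go, is whether an amine, a carboxylic acid or a longer chain at this place would give an actual number, and how that number would compare with compound 2.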